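Pyridinyl to thienyl exchange on a triaryl pyridine core

The compounds below may be only part of what the source reports. "The series", "measured", "known", "first", "only" and "open" are said of these compounds alone.

Measured compounds:
- compound 1: `Oc1cccc(-c2cc(-c3cccnc3)nc(-c3cccc(Cl)c3)c2)c1` — "not determined" (no result reported)
- compound 2: `Oc1cccc(-c2cc(-c3ccc(Cl)cc3)nc(-c3cccnc3)c2)c1` — 18100 nM

In a functional assay on T47D cells (Homo sapiens) for cytotoxicity, read by CCK-8 assay and cell counting, with a stated time of 2 days (on this read-out lower numbers stand for stronger inhibition and higher numbers for weaker inhibition), compound 1 gives "not determined" (no result reported), so its standing on this read-out is open. Within the data shown here, the one measured neighbour, compound 2, gives 18100 nM in this assay, a weak result. Compound 2 and compound 1 are not a listed pair, so nothing is known of the step between them; compound 2 only shows that this type of core with a chlorophenyl, a hydroxyphenyl and a pyridin-3-yl group sits in the weak range.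

Compound 3 is `Oc1cccc(-c2cc(-c3cccc(Cl)c3)nc(-c3cccs3)c2)c1`. The change from compound 1 to compound 3 is thiophen-2-yl in place of pyridin-3-yl on an aromatic carbon. Among the measured compounds shown here, only one value is known for the whole series, so no size of step in this assay can be anchored; the expectation is that the exchange of one small aromatic ring for another of similar shape moves the value by no more than the usual scatter, with no clear direction, and that compound 3 stays close to the weak range that compound 2 shows.

For compound 3 the estimated value in this assay is 15000 nM, with a range from 4000 nM to 60000 nM.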

Compound 3, half-maximal inhibitory concentration: 3410 nM
Compound 3: middle estimate off by 4.4-fold (0.64 log units), on the high side; the whole stated range lies above it.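

In this assay, among these compounds, compound 1 gives "not determined" (no result reported) and compound 3 gives 3410 nM as the only number of the pair, so no step can be read from compound 1 to compound 3. Going by these compounds, how thiophen-2-yl in place of pyridin-3-yl shifts the value on the shared core stays open. No evidence bearing on this result is available.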